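This account rests on a few compounds, and the source may have more. Where it says the series, first, only, none or still open, it means among the compounds named here.

Compound 1 `COc1ccccc1Nc1nc(SCc2cn(Cc3ccccc3Cl)nn2)nc(-c2ccccc2)c1C#N` gives 6170 nM in a functional assay on MCF7 cells (Homo sapiens) for inhibition, read by MTT assay, with a stated time of 72 h; a lower number here means a stronger inhibitor, a higher number a weaker inhibitor. Compound 2 `Cc1ccc(Nc2nc(SCc3cn(Cc4ccc(Cl)cc4)nn3)nc(-c3ccccc3)c2C#N)cc1` reaches only the limit of this assay, > 64000 nM, so no number is known for it (the limit of > 64000 nM in this assay, at which 1 of the 2 values shown sits). Compound 3 `Cc1ccc(Nc2nc(SCc3cn(Cc4ccccc4Cl)nn3)nc(-c3ccccc3)c2C#N)cc1` carries 2-chlorophenyl in place of 4-chlorophenyl on a saturated chain carbon bound to an aromatic nitrogen. Within the data shown here, no measured pair shows this change alone, so its size and direction here are unknown; with compound 2 sitting at a limit, any downward step would be within what that limit leaves open. Compound 3 is therefore expected at 30000 nM, in the range 8000 nM to 100000 nM, meaning an expected step of an at least 2.1-fold lower number from compound 2 to compound 3 (0.32 log units; beyond the scatter).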

Compound 3, half-maximal inhibitory concentration: 9420 nM
Compound 3: middle estimate off by 3.2-fold (0.50 log units), on the high side; low and high end bracket the measured number.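

With 2-chlorobenzyl in place of 4-chlorobenzyl, on a saturated chain carbon bound to an aromatic nitrogen, this assay shows an at least 6.7-fold lower number from compound 2 to compound 3 (0.83 log units; beyond the scatter), the first step read at this place. The value of compound 2 is a limit, not a number: the limit of > 64000 nM in this assay, at which 1 of the 3 values shown sits.

With 2-chlorobenzyl held fixed, 4-methylphenyl in place of 2-methoxyphenyl on a nitrogen on an aromatic ring gives a 1.5-fold higher number from compound 1 to compound 3 (0.18 log units; within the scatter). Going by these compounds, how a plain benzyl, or bromine in place of the chlorine, would read at this place in this assay stays open.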